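Leaving the limit at compound 3: the step to compound 4

This account rests on a few compounds, and the source may have more. Where it says the series, first, only, none or still open, it means among the compounds named here.

In a functional assay on PC-3 cells (Homo sapiens) for antiproliferative activity, read by MTT assay, with a stated time of 48 h (on this read-out lower numbers stand for stronger inhibition and higher numbers for weaker inhibition), compound 1 `CCn1c(C(=O)NCC#N)ccc1C(CC)(CC)c1ccc(OCCC(O)(CC)CC)c(C)c1` gives 17800 nM and compound 2 `CCn1c(C(=O)NCCN)ccc1C(CC)(CC)c1ccc(OCCC(O)(CC)CC)c(C)c1` gives 2420 nM. Compound 3 `CCOc1ccc(NC(=O)c2ccc(C(CC)(CC)c3ccc(OCCC(O)(CC)CC)c(C)c3)n2CC)cc1` gives > 50000 nM, which is a limit of the assay and not a number. That places compound 3 at the limit of > 50000 nM in this assay, at which 1 of the 3 values shown sits.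

Compound 4 `CCOC(=O)CN(C)C(=O)c1ccc(C(CC)(CC)c2ccc(OCCC(O)(CC)CC)c(C)c2)n1CC` differs from compound 3 as follows: ((ethoxycarbonyl)methyl)(methyl)amino in place of (4-ethoxyphenyl)amino on a carbonyl carbon. The 4-ethoxyphenyl group therefore leaves the series again. Two measured steps bring that group in on an amide-type nitrogen: an at least 2.8-fold higher number from compound 1 to compound 3 (0.44 log units; beyond the scatter) and an at least 20-fold higher number from compound 2 to compound 3 (1.31 log units; beyond the scatter). Both rise in number, so a lower number is expected on its removal in this assay. The size is less certain, since a 7.4-fold lower number from compound 1 to compound 2 (0.87 log units; beyond the scatter) shows that the non-aryl amides themselves differ. The incoming group is not represented among the measured compounds, so the expectation stays near compound 1 at 17800 nM. There is also a real chance that compound 4 reaches the limit of the assay as well.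

The expected change is an at least 2.5-fold lower number from compound 3 to compound 4 (0.39 log units; beyond the scatter). Compound 4 is estimated at 20000 nM, with an expected range of 6000 nM to 50000 nM.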

Compound 4, half-maximal inhibitory concentration: 7140 nM
For compound 4 the middle estimate is 2.8-fold (0.45 log units) above the measured one; measured number inside the range.
By their numbers in this assay, from the lowest: compound 2; then compound 4; then compound 1. At a limit, above all of these: compound 3.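

In this assay, ((ethoxycarbonyl)methyl)(methyl)amino on the carbonyl carbon gives a measurable number where (4-ethoxyphenyl)amino does not, with an at least 7.0-fold lower number from compound 3 to compound 4 (0.84 log units; beyond the scatter). Compound 3 stands at a limit of the assay, so that step is only a bound: the limit of > 50000 nM in this assay, at which 1 of the 4 values shown sits. Among the amides without an aryl group, the new group falls on both sides of the earlier values, with a 2.5-fold lower number from compound 1 to compound 4 (0.40 log units; beyond the scatter) and a 3.0-fold higher number from compound 2 to compound 4 (0.47 log units; beyond the scatter), and compound 2 keeps the lowest number of the series.

The incoming group changes several features at once, so the separate shares of the methyl on nitrogen and of the ethyl ester remain unresolved. Also open, going by these compounds, is how the number moves with a carboxylic acid in place of the ethyl ester, or with the amide hydrogen in place of the methyl.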